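Series notes: compound 3, a new group on the shared core

The compounds below may be only part of what the source reports. "The series", "measured", "known", "first", "only" and "open" are said of these compounds alone.

For the measured compounds named here, compound 2 `NS(=O)(=O)c1ccc(-c2cnc(C(=O)CCCCCCc3ccccc3)o2)s1` gives the lowest of the two numbers measured so far in an assay (Rattus norvegicus) for inhibition of Fatty-acid amide hydrolase 1 (Homo sapiens) (on this read-out higher numbers stand for weaker inhibition and lower numbers for stronger inhibition), at 3 nM; its nearest neighbour is compound 1 `N#Cc1ccccc1-c1cnc(C(=O)CCCCCCc2ccccc2)o1`, which in this assay gives 130 nM. Going by the values given here, the one step known, a 43-fold lower number from compound 1 to compound 2 (1.64 log units; beyond the scatter), is large and beyond the scatter, and it turns on exactly the group that sits on the aromatic carbon of the shared core.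

Compound 3 `O=C(CCCCCCc1ccccc1)c1ncc(-c2cc(=O)[nH]c(=O)[nH]2)o1` changes that same group again: a group of 8 heavy atoms (4 carbon, 2 nitrogen, 2 oxygen; one six-membered aromatic ring with 2 hetero atoms) in place of a group of 9 heavy atoms (4 carbon, 1 nitrogen, 2 oxygen, 2 sulfur; one five-membered aromatic ring with 1 hetero atom), on an aromatic carbon. The step from compound 1 to compound 2 bears on it directly, since it shows that the number in this assay moves strongly when this group is exchanged. That step does not tell which way a further exchange will go, and the entering group has no measured relative in the series. The expectation is therefore a step of uncertain direction but possibly large, with the number more likely to rise than to fall from the low value of compound 2.

For compound 3 the estimate in this assay is 30 nM, with a range of 3 nM to 300 nM, which is expected to amount to a 10-fold higher number from compound 2 to compound 3 (1.00 log units; beyond the scatter).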

Compound 3, inhibition constant: 12 nM
Compound 3: middle estimate off by 2.5-fold (0.40 log units), on the high side, and the stated range covers the measured number.
By their numbers in this assay, from the lowest: compound 2; then compound 3; then compound 1.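

In this assay, a second group on this aromatic carbon also gives a clear gain over 2-cyanophenyl, with an 11-fold lower number from compound 1 to compound 3 (1.03 log units; beyond the scatter) on the exchange, so a low number here is not confined to 5-sulfamoylthiophen-2-yl. The two better groups still do not match, as shown by a 4.0-fold higher number from compound 2 to compound 3 (0.60 log units; beyond the scatter) in this series, and this gap is the smaller of the two new steps. The groups of compound 1 and compound 3 each hold 8 heavy atoms and a six-membered aromatic ring, so neither that count nor that ring size alone sets the number at this position.

Going by these compounds, it remains open whether the gain follows the ring itself or what the ring carries, which a plain phenyl, an unsubstituted thiophen-2-yl or a carboxylic acid on the same carbon would help to separate. On these data alone, it is also open whether the order of these three groups would hold with a shorter chain on the carbonyl. Nothing available here gives a reason for the differences between these groups.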